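A few compounds are considered here, and "the series" means these few. Any claim that something is new, unique, unknown or untested is made for them only; others in the source may bear on it.

Of the compounds shown here, three have so far been measured in an assay on MDA-MB-231 cells for displacement of a labelled ligand from C-X-C chemokine receptor type 4 (Homo sapiens), read by fluorescence and microscopy, with stated times of 10 min and 30 min; on this read-out higher numbers stand for an effect only at larger amounts of compound and lower numbers for an effect already at smaller amounts. Compound 3 `COc1ccccc1C(=O)NCc1ccc(CNS(=O)(=O)c2ccc(F)cc2)cc1` gives 100 nM. Compound 1 `COc1ccccc1C(=O)NCc1ccc(CNS(=O)(=O)c2cccc(C)c2)cc1` gives 1000 nM; the change between them is 3-methylphenyl in place of 4-fluorophenyl on a sulfonyl sulfur, and it brought a 10-fold higher number from compound 3 to compound 1 (1.00 log units; beyond the scatter). Compound 2 `Cc1ccccc1C(=O)NCc1ccc(CNS(=O)(=O)c2ccc(F)cc2)cc1` gives 10 nM, the lowest number of the three; it differs from compound 3 by methyl in place of methoxy on an aromatic carbon, with a 10-fold higher number from compound 2 to compound 3 (1.00 log units; beyond the scatter). Compound 4 `Cc1cccc(S(=O)(=O)NCc2ccc(CNC(=O)c3ccccc3C)cc2)c1` has not yet been measured. Among the compounds with values here, it differs from compound 2 by 3-methylphenyl in place of 4-fluorophenyl on a sulfonyl sulfur, the same change as the one from compound 3 to compound 1, made at the same place; only the core differs, in the way described for compound 3 and compound 2. The step from compound 2 to compound 4 is expected to be a 10-fold higher number from compound 2 to compound 4 (1.00 log units; beyond the scatter) because a 10-fold higher number from compound 3 to compound 1 (1.00 log units; beyond the scatter) was seen with this change. Compound 4 is thus estimated at 100 nM, resting on that single earlier step.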

Compound 4, effective concentration (reported as EC, without a stated level of effect): 1000 nM
For compound 4 the middle estimate is 10-fold (1.00 log units) below the measured one; measured number outside the range, above it.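

In this assay, within the data shown here, 3-methylphenyl in place of 4-fluorophenyl on a sulfonyl sulfur gave a higher number on both cores, but the size of the step did not carry over, with a 100-fold higher number from compound 2 to compound 4 (2.00 log units; beyond the scatter) on the second core: the same change on two cores in this assay, a 10-fold higher number (1.00 log units; beyond the scatter) from compound 3 to compound 1 and a 100-fold higher number (2.00 log units; beyond the scatter) from compound 2 to compound 4, 10-fold (1.00 log units) apart, beyond the scatter of two such steps The swap between methoxy and methyl on an aromatic carbon did not carry over either, giving no change at the digits printed from compound 1 to compound 4 (within the scatter) once 3-methylphenyl was present: the same change on two cores in this assay, a 10-fold higher number (1.00 log units; beyond the scatter) from compound 2 to compound 3 and no change at the digits printed (within the scatter) from compound 4 to compound 1, 10-fold (1.00 log units) apart, beyond the scatter of two such steps So the effects of these two changes do not simply add up in these four compounds, but this does not show why, and with only two cores it gives no general rule for the series.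

The compounds shown leave open how other groups on the sulfonyl sulfur, such as a phenyl ring carrying an amine or a carboxylic acid, would behave on either core.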